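The source may hold more compounds than are shown below. What is called first, only, known or untested is meant among the compounds shown, and "the series" means these compounds.

Working notes on the series.

Compound 1 `CCc1cnc(N2CCC(Oc3ncnc4c(-c5ccc(C(=O)N(C)OC)cc5)csc34)CC2)nc1` gives 199 nM in a functional assay on cells for agonist activity at Glucose-dependent insulinotropic receptor (Homo sapiens), read by a luciferase reporter, with a stated time of 6 h; on this read-out higher numbers stand for an effect only at larger amounts of compound and lower numbers for an effect already at smaller amounts. Compound 2 `CCc1cnc(N2CCC(Oc3ncnc4c(-c5ccc(C(=O)N(C)OC)c(F)c5)csc34)CC2)nc1` differs from compound 1 by fluoro in place of hydrogen on an aromatic carbon; in this assay compound 2 gives 105 nM, and the step of a 1.9-fold lower number from compound 1 to compound 2 (0.28 log units; within the scatter) is the only measured record of this change in the set. Compound 3 `CON(C)C(=O)c1ccc(-c2ccc(OCC3CCN(C(=O)OC(C)(C)C)CC3)cn2)cc1` has a different core; the difference between the two cores is not broken down here. In this assay compound 3 gives 171 nM, close to compound 1.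

Compound 4 `CON(C)C(=O)c1ccc(-c2ccc(OCC3CCN(C(=O)OC(C)(C)C)CC3)cn2)cc1F` has not yet been measured. It differs from compound 3 by fluoro in place of hydrogen on an aromatic carbon, at a place described in the same words as for compound 2, so the change is the same one. For compound 4 the step of a 1.7-fold lower number from compound 3 to compound 4 (0.23 log units; within the scatter) is expected, resting on the step of a 1.9-fold lower number from compound 1 to compound 2 (0.28 log units; within the scatter) seen in this assay. Compound 4 is therefore estimated at 100 nM, between 40 nM and 250 nM.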

Compound 4, half-maximal effective concentration: 73 nM
Estimate against measurement, compound 4: 1.4-fold (0.14 log units) above, and the stated range covers the measured number.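

In this assay fluoro in place of hydrogen on an aromatic carbon gives a 2.3-fold lower number from compound 3 to compound 4 (0.37 log units; beyond the scatter), a modest step. Set beside the earlier step, it agrees in size on the two cores: the same change on two cores in this assay, a 1.9-fold lower number (0.28 log units; within the scatter) from compound 1 to compound 2 and a 2.3-fold lower number (0.37 log units; beyond the scatter) from compound 3 to compound 4, 1.2-fold (0.09 log units) apart, within the scatter of two such steps. For the compounds shown here, this supports carrying the change between these two cores in this assay, but only the step on the core of compound 3 lies beyond the scatter, and two pairs neither give a rule for other cores nor show why the number moves.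

The compounds shown leave open whether chloro or methyl at the same place would give a similar step. Also open, as far as these compounds go, is whether the fluoro step would persist with a carboxylic acid in place of the methoxy(methyl)carbamoyl group.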